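This account rests on a few compounds, and the source may have more. Where it says the series, first, only, none or still open, it means among the compounds named here.

Measured so far in a functional assay on the whole organism for inhibition, with Mus musculus as the target; on this read-out higher numbers stand for an effect only at larger amounts of compound and lower numbers for an effect already at smaller amounts:
compound 1 `CCN1CCCC1CNC(=O)c1cc(N(C)S(C)(=O)=O)ccc1OC` — 22.9 mg/kg
compound 2 `CCN1CCCC1CNC(=O)c1cc(NS(=O)(=O)N(C)C)ccc1OC` — > 50 mg/kg (a limit of the assay, not a number)
compound 3 `CCN1CCCC1CNC(=O)c1cc(NS(=O)(=O)N(C)C)c(Cl)cc1OC` — 8.3 mg/kg

Compound 2 stands at the upper edge of the series: in this assay it reached only (the limit of > 50 mg/kg in this assay, at which 1 of the 3 values shown sits), so no number is known for it. Against it, compound 1 gives 22.9 mg/kg and compound 3 gives 8.3 mg/kg.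

Compound 4 `CCN1CCCC1CNC(=O)c1cc(N(C)S(=O)(=O)N(C)C)ccc1OC` differs from compound 2 by methyl in place of hydrogen on a sulfonamide nitrogen. Of the measured steps, the one that bears on this is an at least 2.1-fold higher number from compound 1 to compound 2 (0.33 log units; beyond the scatter), which took away the methyl on the sulfonamide nitrogen together with the change of the sulfonyl part; compound 4 restores the methyl while keeping the dimethylsulfamoyl group, so it lies between compound 1 and compound 2. The step of an at least 6.0-fold lower number from compound 2 to compound 3 (0.77 log units; beyond the scatter) concerns a chloro on the ring and does not touch this position.

Since compound 2 is only a limit, the size of the step cannot be fixed; the expectation is a modest lowering of the number, an at least 1.6-fold lower number from compound 2 to compound 4 (0.22 log units; that floor lies within the scatter). Compound 4 is accordingly estimated at 30 mg/kg, within 10 mg/kg to 90 mg/kg, with a real chance that the assay again reports only a limit.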

Compound 4, dose for half-maximal effect: 36.2 mg/kg
Compound 4: the middle estimate sits 1.2-fold (0.08 log units) below what was measured; the range from low to high includes it.
By their numbers in this assay, from the lowest: compound 3; then compounds 1 and 4 (each within the scatter of the next). At a limit, above all of these: compound 2.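

In this assay, methyl on the sulfonamide nitrogen of compound 2 gives an at least 1.3-fold lower number from compound 2 to compound 4 (0.14 log units; that floor lies within the scatter) and so turns a limit into a number, but the floor of this step does not establish a real gain and its true size stays unfixed. Compound 2 remains a limit of the assay, not a number: the limit of > 50 mg/kg in this assay, at which 1 of the 4 values shown sits.
With the methyl kept on that nitrogen, the change on the sulfonyl sulfur alone gives a 1.6-fold higher number from compound 1 to compound 4 (0.20 log units; within the scatter) and thus separates the two changes that were joined in the earlier step to compound 2, with dimethylamino and methyl not told apart here.

On these data alone, whether ethyl or a longer chain on the sulfonamide nitrogen is tolerated as well as methyl remains open. Also open, as far as these compounds go, is whether the chloro of compound 3 would shift the number of compound 4 as it does for compound 2.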